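Anilinothiophene ester series: halogen swap on the aniline ring

The source may hold more compounds than are shown below. What is called first, only, known or untested is meant among the compounds shown, and "the series" means these compounds.

Measured compounds:
compound 1 `COC(=O)c1c(Nc2ccccc2)sc(C(=O)c2ccc(C)cc2)c1C`: in a functional assay, with a stated time of 150 min, tested at 30 ug/mL (a higher number here means a stronger effect of the compound at the concentration tested, a lower number a weaker effect), compound 1 gives 9.35%
compound 2 `COC(=O)c1c(Nc2ccc(F)cc2)sc(C(=O)c2ccc(C)cc2)c1C`: in this assay compound 2 is reported as "not active" (no number reported)

In this assay compound 1 shows only a weak effect at the concentration tested, and its reading sits within the usual scatter of the zero line. Compound 2 has no single number to stand on: the report for it is a bare statement of inactivity, so all that can be said is that nothing measurable was seen, and the two values together point to a series that is at best marginal here. Compound 3 `COC(=O)c1c(Nc2ccc(Cl)cc2)sc(C(=O)c2ccc(C)cc2)c1C` has not been measured. Relative to compound 2 the change is chloro in place of fluoro on an aromatic carbon, with the rest of the molecule untouched. Nothing measured in the series gives a reason to expect movement, so the expected step in this assay is none beyond the scatter, in either direction. For compound 3 in this assay an activity of 5% is estimated, with a range from -5% to 15%, and a sizeable chance that only inactivity is reported again.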

Compound 3, a percentage reported as activity, at one concentration (the size of the read-out at that concentration, not a potency): "not active" (no number reported)
The entry for compound 3 holds no number; there is nothing to compare the estimate with.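

In this assay compound 2 and compound 3 are both reported only as inactive, with no number, so no step can be read between them. The compounds shown leave open whether chloro in place of fluoro changes the effect at all in this assay. No evidence on hand bears on this result.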